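Longer alkoxy chain on a hydroxymethyl-bearing furan series

The compounds below may be only part of what the source reports. "The series", "measured", "known", "first", "only" and "open" are said of these compounds alone.

Compound 1 `CCOc1c(-c2occ(C)c2C(=O)O)ccc2c(CC)cccc12` gives in a functional assay on SK-BR-3 cells (Homo sapiens) for cytotoxicity, read by MTT assay, with a stated time of 72 h (on this read-out higher numbers stand for an effect only at larger amounts of compound and lower numbers for an effect already at smaller amounts), the limit > 10 ug/mL, which is a limit of the assay and not a number.
Compound 2 `CCOc1c(-c2occ(C)c2C(=O)OC)ccc2c(CC)cccc12` gives in this assay a value of 1.9 ug/mL.
Compound 3 `CCc1cccc2c(OC)c(-c3occ(C)c3CO)ccc12` gives in this assay a value of 0.73 ug/mL.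

Compound 3 holds the lowest of the two numbers; compound 2 sits higher, and that gap lies beyond the scatter. Compound 4 `CCOc1c(-c2occ(C)c2CO)ccc2c(CC)cccc12` differs from compound 3 by methyl in place of hydrogen on a saturated chain carbon bound to an oxygen on an aromatic ring. Among the compounds with values here, the only measured step, an at least 5.2-fold lower number from compound 1 to compound 2 (0.72 log units; beyond the scatter), concerns methyl in place of hydrogen on an oxygen next to a carbonyl group and does not touch the change from compound 3 to compound 4, so no measured step bears on it. The step of a 1.1-fold higher number from compound 3 to compound 4 (0.04 log units; within the scatter) is therefore expected to stay within the scatter. Compound 4 is expected at 0.8 ug/mL, with a range from 0.3 ug/mL to 2.5 ug/mL.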

Compound 4, concentration for half-maximal effect: 8.8 ug/mL
The estimate for compound 4 lay 11-fold (1.04 log units) below the measured number; the measured number lies above the stated range.
By their numbers in this assay, from the lowest: compound 3; then compound 2; then compound 4. At a limit, above all of these: compound 1.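

Methyl in place of hydrogen on a saturated chain carbon bound to an oxygen on an aromatic ring turns methoxy into ethoxy and raises the number in this assay: a 12-fold higher number from compound 3 to compound 4 (1.08 log units; beyond the scatter). With ethoxy kept, hydroxymethyl in place of methoxycarbonyl on an aromatic carbon also goes with a rise: a 4.6-fold higher number from compound 2 to compound 4 (0.67 log units; beyond the scatter). Hydroxymethyl in place of carboxy on an aromatic carbon gives an at least 1.1-fold lower number from compound 1 to compound 4 (0.05 log units; that floor lies within the scatter). The size of that step cannot be read, as compound 1 stands at a limit, not a number: the limit of > 10 ug/mL in this assay, at which 1 of the 4 values shown sits.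

Going by these compounds, whether a longer chain at this oxygen raises the number further remains open. So does whether methoxy paired with a methoxycarbonyl or carboxylic acid group gives the same step.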